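The source may hold more compounds than are shown below. What is called first, only, known or untested is meant among the compounds shown, and "the series" means these compounds.

Compound 3 `O=C(Nc1ccc(Oc2ccnc3[nH]ccc23)c(F)c1)c1cn(-c2ccc(Br)cc2)c2ccccc2c1=O` gives 650 nM in a functional assay on MCF7 cells (Homo sapiens) for inhibition, read by MTT assay, with a stated time of 72 h; on this read-out lower numbers stand for stronger inhibition and higher numbers for weaker inhibition. Compound 2 `O=C(Nc1ccc(Oc2ccnc3[nH]ccc23)c(F)c1)c1cn(-c2ccccc2)c2ccccc2c1=O` gives 430 nM in this assay; the step of a 1.5-fold higher number from compound 2 to compound 3 (0.18 log units; within the scatter) lies within the scatter. A third member of the series, compound 1 `O=C(Nc1ccc(Oc2ccnc3[nH]ccc23)cc1)c1cn(-c2ccc(Br)cc2F)c2ccccc2c1=O`, has "not determined" (no result reported) in this assay and therefore adds nothing to the comparison.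

Compound 4 `O=C(Nc1ccc(Oc2ccnc3[nH]ccc23)c(F)c1)c1cn(-c2ccc(Br)cc2F)c2ccccc2c1=O` differs from compound 3 in one place: fluoro in place of hydrogen on an aromatic carbon. Within the data shown here, the only measured step that bears on this is the one from compound 2 to compound 3, which also exchanges a hydrogen on the same aromatic ring for a halogen and which stayed within the scatter. Among the measured compounds shown here, with a single step of that kind available, and no measured pair that adds a fluoro to a ring that already carries the bromo, there is no ground for expecting a shift in this assay beyond the scatter in either direction.

For compound 4 the expected number in this assay is therefore 650 nM, with a range of 300 nM to 1400 nM, which amounts to an expected step of no change at the digits printed from compound 3 to compound 4 (within the scatter).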

Compound 4, half-maximal inhibitory concentration: 1390 nM
Compound 4: middle estimate off by 2.1-fold (0.33 log units), on the low side; measured number inside the range.
By their numbers in this assay, from the lowest: compounds 2 and 3 (each within the scatter of the next); then compound 4.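

In this assay, among these compounds, fluoro in place of hydrogen on the aromatic carbon ortho to a large group and meta to a bromo group gives a 2.1-fold higher number from compound 3 to compound 4 (0.33 log units; beyond the scatter) and is the first change on this ring to pass the scatter. The bromo alone had stayed within the scatter with a 1.5-fold higher number from compound 2 to compound 3 (0.18 log units; within the scatter), whereas 4-bromo-2-fluorophenyl in place of phenyl on the aromatic nitrogen gives a 3.2-fold higher number from compound 2 to compound 4 (0.51 log units; beyond the scatter), so among these compounds a step beyond the scatter on this ring appears only with both halogens present. Nothing available gives a reason for this step.

The compounds shown leave open whether fluoro on a phenyl ring without the bromo would also raise the number, and so whether the step depends on the bromo being there. They also leave open how this aromatic carbon would respond to a chloro, a methyl, a methoxy or an amine in place of the fluoro, and whether a nitrile in place of the bromo would give a step of the same size.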